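This account rests on a few compounds, and the source may have more. Where it says the series, first, only, none or still open, it means among the compounds named here.

Measured so far:
compound 1 `O=C(Nc1cccnc1)c1ccccc1OCc1ccccc1F`: 3500 nM
compound 2 `O=C(Nc1cccnc1)c1ccccc1OCc1cccc(Cl)c1`: 1400 nM

Both numbers come from an assay on lysate for inhibition of phosphatidylcholine:ceramide cholinephosphotransferase 2 (Homo sapiens), read by HPLC, with stated times of 30 min and 2 h; a lower number here means a stronger inhibitor, a higher number a weaker inhibitor. Compound 1 stands at the higher of the two numbers; its nearest neighbour is compound 2, reached by the step of a 2.5-fold lower number from compound 1 to compound 2 (0.40 log units; beyond the scatter), a modest change made by exchanging the ring on the saturated carbon bound to the aryl oxygen. Compound 3 `O=C(Nc1cccnc1)c1ccccc1OCc1ccccc1OCCCCCl` alters compound 1 in a different way: 4-chlorobutoxy in place of fluoro on an aromatic carbon. The rest of the structure is kept as in compound 1.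

Within the data shown here, no measured step covers a change on that aromatic carbon. Among the measured compounds shown here, the single step in hand, from compound 1 to compound 2, concerns a different position, so it gives no direct guide, only a sense that changes in this part of the molecule have so far been modest. Compound 3 is therefore expected to land near compound 1, at about 2500 nM, with a range from 700 nM to 9000 nM. The expected step is a 1.4-fold lower number from compound 1 to compound 3 (0.15 log units; within the scatter), not clearly beyond the scatter in either direction.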

Compound 3, half-maximal inhibitory concentration: 1300 nM
For compound 3 the middle estimate is 1.9-fold (0.28 log units) above the measured one; low and high end bracket the measured number.
By their numbers in this assay, from the lowest: compounds 3 and 2 (each within the scatter of the next); then compound 1.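

In this assay, among these compounds, 4-chlorobutoxy in place of fluoro on this aromatic carbon, ortho to a large group, gives a 2.7-fold lower number from compound 1 to compound 3 (0.43 log units; beyond the scatter) as the first reading at this position. The number falls rather than rises, so an entering group of 6 heavy atoms is accepted here in place of a single fluorine atom, at least for this chain. No measurement at hand bears on what lies behind the step.

The compounds shown do not separate the contributions of the ether oxygen, the chain length and the chlorine of the chain, all of which enter together in 4-chlorobutoxy. Open, as far as these compounds go, are methoxy, butoxy without the chlorine, and a butoxy chain carrying an amine or a carboxylic acid at this position.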